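The compounds below may be only part of what the source reports. "The series", "measured", "known", "first", "only" and "open" are said of these compounds alone.

Of the compounds shown here, three that share one core have so far been measured in an assay on isolated protein for inhibition of histone deacetylase 4 (Homo sapiens), with a stated time of 1 h; on this read-out lower numbers stand for stronger inhibition and higher numbers for weaker inhibition. Compound 3 `O=C(COc1ccc2cc(/C=C3/SC(=O)NC3=O)ccc2c1)Nc1c(F)cc(F)cc1Br` gives 1100 nM, the lowest of the three numbers. Compound 1 `O=C(COc1ccc2cc(/C=C3/SC(=O)NC3=O)ccc2c1)Nc1ccc([N+](=O)[O-])cc1` gives 1700 nM, and compound 2 `COc1ccc(NC(=O)COc2ccc3cc(/C=C4/SC(=O)NC4=O)ccc3c2)cc1` gives 4700 nM. Between compound 1 and compound 3 the step is a 1.5-fold lower number from compound 1 to compound 3 (0.19 log units; within the scatter), so these two cannot be put in order; the step from compound 2 to compound 3 is larger, a 4.3-fold lower number from compound 2 to compound 3 (0.63 log units; beyond the scatter), and from compound 1 to compound 2 there is a 2.8-fold higher number from compound 1 to compound 2 (0.44 log units; beyond the scatter).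

Compound 4 `O=C(COc1ccc2cc(/C=C3/SC(=O)NC3=O)ccc2c1)Nc1ccc(Br)cc1` has not yet been measured. It differs from compound 3 in one place: 4-bromophenyl in place of 2-bromo-4,6-difluorophenyl on an amide-type nitrogen. For the measured compounds named here, two measured steps bear on this change, both being exchanges of the aryl group on the amide-type nitrogen: a 1.5-fold lower number from compound 1 to compound 3 (0.19 log units; within the scatter) and a 4.3-fold lower number from compound 2 to compound 3 (0.63 log units; beyond the scatter). The aryl groups of compound 1 and compound 2, each carrying a single substituent, gave numbers no lower than compound 3, one within the scatter and one modestly beyond it. Compound 4 is therefore expected to give a somewhat higher number than compound 3, a step estimated at a 1.8-fold higher number from compound 3 to compound 4 (0.26 log units; within the scatter), probably near the edge of the scatter. The estimate for compound 4 in this assay is 2000 nM, within a range from 900 nM to 4500 nM.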

Compound 4, half-maximal inhibitory concentration: 2900 nM
The estimate for compound 4 lay 1.5-fold (0.16 log units) below the measured number, and the stated range covers the measured number.
By their numbers in this assay, from the lowest: compounds 3, 1, 4 and 2 (each within the scatter of the next, the first and the last beyond it).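

In this assay, for the compounds shown here, the exchange of 2-bromo-4,6-difluorophenyl for 4-bromophenyl on the amide-type nitrogen gives a step beyond the scatter (a 2.6-fold higher number from compound 3 to compound 4 (0.42 log units; beyond the scatter)), the first comparison at this position in which bromine is present on both aryl groups. The two fluorines leave in this change and the bromine also sits at a different place on the ring, so the step cannot be assigned to either difference alone. Against the other singly substituted aryl groups, neither bromo in place of methoxy (a 1.6-fold lower number from compound 2 to compound 4 (0.21 log units; within the scatter)) nor bromo in place of nitro (a 1.7-fold higher number from compound 1 to compound 4 (0.23 log units; within the scatter)) leaves the scatter, so compound 4 cannot be put in order against compound 1 or compound 2, and the 2-bromo-4,6-difluorophenyl group stands apart from the 4-bromophenyl and 4-methoxyphenyl groups but not from the 4-nitrophenyl group of compound 1.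

Nothing shown here gives a reason for the step from compound 3. Also open, as far as these compounds go, is how this position would respond to a 2-bromophenyl group, a 2,4-difluorophenyl group, or an aryl group carrying an amine or a carboxylic acid.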